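Swapping the Aryl Group on the Ring Nitrogen

A few compounds are considered here, and "the series" means these few. Any claim that something is new, unique, unknown or untested is made for them only; others in the source may bear on it.

Compound 1 `COc1ccc(C)cc1N1C(=O)CSC1c1cccc(C(=O)NCCCCc2ccccc2)c1` gives 300 nM in a functional assay on HOS-TE85 cells (Homo sapiens) for inhibition, read by CCK-8 assay, with a stated time of 72 h (on this read-out lower numbers stand for stronger inhibition and higher numbers for weaker inhibition), the highest of the three numbers measured here. Compound 2 `Cc1ccnc(N2C(=O)CS[C@@H]2c2cccc(C(=O)NCCCCn3cccn3)c2)c1` gives 21.9 nM in this assay and compound 3 `COc1ccccc1N1C(=O)CSC1c1cccc(C(=O)NCCCCc2cccs2)c1` gives 46 nM; both numbers lie beyond the scatter from that of compound 1, yet both compounds differ from compound 1 in more than one place, so neither gap can be tied to a single change. Compound 4 `COc1ccc(N2C(=O)CSC2c2cccc(C(=O)NCCCCc3ccccc3)c2)c(OC)c1` differs from compound 1 in one place: 2,4-dimethoxyphenyl in place of 2-methoxy-5-methylphenyl on an amide-type nitrogen in a ring. Among the measured compounds shown here, no measured pair isolates such a change. The expected step of a 1.5-fold lower number from compound 1 to compound 4 (0.18 log units; within the scatter) is small, toward a lower number, and not clearly beyond the scatter. Compound 4 is therefore expected to give about 200 nM, within a range from 60 nM to 700 nM.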

Compound 4, half-maximal inhibitory concentration: 90.4 nM
Compound 4: the middle estimate sits 2.2-fold (0.34 log units) above what was measured; the measured number falls inside the stated range.
By their numbers in this assay, from the lowest: compound 2; then compounds 3 and 4 (each within the scatter of the next); then compound 1.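

In this assay, among the compounds shown here, the step of a 3.3-fold lower number from compound 1 to compound 4 (0.52 log units; beyond the scatter) is the first change here that can be read at a single place, the amide-type nitrogen in a ring. It shows that the aryl group at this position can shift the number with the rest of compound 1 held fixed, by a modest step that lies beyond the scatter. Nothing at hand explains this step.

On these data alone, a methyl group leaves and a second methoxy enters in the same change, so their separate shares stay unknown. As far as these compounds go, how an amine or a carboxylic acid on this phenyl ring would behave also remains open.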